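Swapping 3-fluorobenzyl for 1-phenylethyl on the shared core

The source may report more compounds than this note shows. Statements on the series, on what has been measured and on what is new or still open speak of the compounds shown alone.

Measured in a physicochemical assay for solubility; a lower number here means a less soluble compound, a higher number a more soluble compound:
- Compound 1 `CNC(=O)c1cc(C(=O)NC2CC2)cn(Cc2ccc(F)cc2)c1=O` gives >= 162 ug/mL, a limit of the assay.
- Compound 2 `CNC(=O)c1cc(C(=O)NC2CC2)cn(Cc2ccc(C)cc2)c1=O` gives 24 ug/mL.
- Compound 3 `CNC(=O)c1cc(C(=O)NC2CC2)cn(Cc2cccc(F)c2)c1=O` gives >= 133 ug/mL, a limit of the assay.

Compound 3 therefore has no exact number in this assay, only its limit. The next compound, compound 4 `CNC(=O)c1cc(C(=O)NC2CC2)cn([C@H](C)c2ccccc2)c1=O`, carries 1-phenylethyl in place of 3-fluorobenzyl on an aromatic nitrogen. The fluorine leaves, and the entering group is carbon only, with a defined stereocentre that none of the three measured compounds has.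

Going by the values given here, two measured steps bear on this change. Among the compounds with values here, compound 2, the only measured compound without fluorine, stands apart in an at least 6.7-fold lower number from compound 1 to compound 2 (0.82 log units; beyond the scatter) and again in an at least 5.5-fold higher number from compound 2 to compound 3 (0.74 log units; beyond the scatter). The remaining step is a step that the two limits leave unreadable from compound 1 to compound 3. Compound 4 also lacks fluorine, so a modestly lower number is expected, though its group differs from that of compound 2. The expected step is an at least 2.4-fold lower number from compound 3 to compound 4 (0.38 log units; beyond the scatter). For compound 4 the estimated value is 55 ug/mL, with an expected range from 18 ug/mL to 160 ug/mL.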

Compound 4, solubility: >= 168 ug/mL
Compound 4: no number, only a limit (the forecaster's own chance of this, stated with the estimate: 20%); at least 3.0-fold (0.48 log units) between middle value and limit.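

In this assay compound 4 gives no number, only a limit: the limit of >= 168 ug/mL in this assay, at which 1 of the 4 values shown sits. The readable new step is an at least 7.0-fold higher number from compound 2 to compound 4 (0.84 log units; beyond the scatter), so compound 4 lacks fluorine as compound 2 does and yet does not share its low value, which means that the absence of fluorine does not go with the low value across these compounds. Going by these compounds alone, the steps from compound 1 and from compound 3 to compound 4 each join two limits and cannot be read, so compound 2 remains the only compound of the four with an exact value.

The compounds shown leave open how compound 1, compound 3 and compound 4 truly differ, and whether the opposite stereocentre of 1-phenylethyl would give a similar result. They also leave open what an amine or a carboxylic acid on the aromatic ring of this group would give.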